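This account rests on a few compounds, and the source may have more. Where it says the series, first, only, none or still open, it means among the compounds named here.

Among the measured compounds shown here, compound 1 `O=C(CN(c1ncnc2c1ncn2C1CCCCO1)C1CC1)NCC(=O)OCc1ccccc1` stands at the bottom of the two numbers so far: in a functional assay on the whole organism (Tail, strain ICR) with Mus musculus as the target, in the tail flick test, with a stated time of 150 min, at a dose of 25 umol/kg by the oral route (on this read-out higher numbers stand for a stronger effect at the one dose given and lower numbers for a weaker effect), compound 1 gives 7.26%, the lower of the two. Compound 2 `O=C(CN(c1nc(Cl)nc2[nH]cnc12)C1CC1)N[C@@H](CCC(=O)OCc1ccccc1)C(=O)OCc1ccccc1` is the nearest point of comparison; in this assay compound 2 gives 44.5%, a gap beyond the scatter. For the measured compounds named here, compound 2 differs from compound 1 in more than one place, so its two values can be set side by side but no single step can be drawn from them.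

Compound 3 `N=C(N)NCCC[C@H](NC(=O)CN(c1ncnc2c1ncn2C1CCCCO1)C1CC1)C(=O)OCc1ccccc1` is not yet measured. Relative to compound 1 it carries the change (a group of 7 heavy atoms (4 carbon, 3 nitrogen; no ring) in place of a hydrogen atom, on a saturated chain carbon bound to an amide-type nitrogen and a carbonyl carbon). Going by the values given here, no measured pair in the set isolates this change. The only hint is the higher reading of compound 2, which also carries a group on the saturated chain carbon bound to an amide-type nitrogen and a carbonyl carbon, but its core differs as well, so that reading is not a direct guide. In this assay an upward step is expected, of the size a number 14.7 percentage points higher from compound 1 to compound 3 (beyond the scatter), with wide uncertainty. Compound 3 is estimated to give 22% in this assay, within a range from 5% to 45%.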

Compound 3, a percentage reported as activity, at one dose (the size of the read-out at that dose, not a potency): 19.6%
Estimate against measurement, compound 3: 2.4 percentage points above, and the stated range covers the measured number.
By their numbers in this assay, from the lowest: compound 1; then compound 3; then compound 2.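

In this assay, a group of 7 heavy atoms (4 carbon, 3 nitrogen; no ring) in place of a hydrogen atom, on a saturated chain carbon bound to an amide-type nitrogen and a carbonyl carbon, gives a number 12.3 percentage points higher from compound 1 to compound 3 (beyond the scatter) on an otherwise unchanged structure. Among the compounds shown here, this is the first reading that isolates this position: substitution here, with the core of compound 1 kept, is compatible with a higher reading at the one dose given, though the step is modest and rests on a single pair. Nothing measured on these compounds bears on what lies behind the step.

As far as these compounds go, with one group read at this position, it remains open whether the step follows from the size of the group or from its nitrogen atoms; a methyl group, a 4-aminobutyl chain or a carboxylic acid on the same saturated chain carbon would separate these readings. Also open, from the compounds shown here alone, are whether the same change gives a similar step on another core and how the reading behaves at other doses.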